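The source may report more compounds than this note shows. Statements on the series, on what has been measured and on what is new or still open speak of the compounds shown alone.

Values in a functional assay on CHO cells for agonist activity at Glucose-dependent insulinotropic receptor (Homo sapiens), read by a luciferase reporter and cAMP accumulation, with a stated time of 2 h (on this read-out higher numbers stand for an effect only at larger amounts of compound and lower numbers for an effect already at smaller amounts), for the measured members of the series:

compound 1 `CC(C)(C)OC(=O)N1CCC(CCOC(=O)N2CCc3cc(S(C)(=O)=O)ccc32)CC1`: 68 nM
compound 2 `CC(COC(=O)N1CCc2cc(S(C)(=O)=O)ccc21)C1CCN(C(=O)OC(C)(C)C)CC1`: 8.4 nM
compound 3 `CC(C)(C)OC(=O)N1CCC(C(O)COC(=O)N2CCc3cc(S(C)(=O)=O)ccc32)CC1`: 2400 nM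

Compound 2 stands lowest of the three numbers in this assay. The nearest is compound 1, reached through an 8.1-fold lower number from compound 1 to compound 2 (0.91 log units; beyond the scatter); the furthest is compound 3, reached through a 290-fold higher number from compound 2 to compound 3 (2.46 log units; beyond the scatter). The remaining measured pair gives a 35-fold higher number from compound 1 to compound 3 (1.55 log units; beyond the scatter). All three measured steps concern one and the same place, a saturated chain carbon bound to a saturated chain carbon and a saturated ring carbon, and leave the aromatic part of the shared core untouched.

Compound 4 `CC(COC(=O)N1CCc2cc(S(C)(=O)=O)cc(F)c21)C1CCN(C(=O)OC(C)(C)C)CC1` differs from compound 2 by fluoro in place of hydrogen on an aromatic carbon. None of the measured steps touches an aromatic carbon, so no step among the shown compounds bears on this change, and the data give no basis for expecting movement in this assay in either direction. The working expectation is therefore a step of no size beyond the scatter, with the number for compound 4 near that of compound 2. Compound 4 is expected to give about 8.5 nM in this assay, estimated within 3 nM to 25 nM. This estimate corresponds to an expected 1.0-fold higher number from compound 2 to compound 4 (0.01 log units; within the scatter).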

Compound 4, half-maximal effective concentration: 6.8 nM
Compound 4: the middle estimate sits 1.3-fold (0.10 log units) above what was measured; the range from low to high includes it.
By their numbers in this assay, from the lowest: compounds 4 and 2 (each within the scatter of the next); then compound 1; then compound 3.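

For the compounds shown here, this aromatic carbon, meta to a methylsulfonyl group, is the first place to change outside the saturated chain carbon, and in this assay fluoro in place of hydrogen gives a 1.2-fold lower number from compound 2 to compound 4 (0.09 log units; within the scatter) and so stays within the scatter. Compound 4 therefore keeps the number of compound 2 in the low range, whereas the methyl and hydroxy changes on the chain carbon both moved the number beyond the scatter; this position accepts fluoro without a measurable shift. No measurement of any other kind accompanies this result to account for it.

From the compounds shown here alone, whether this aromatic carbon also accepts chloro, methoxy, nitrile or an amine remains open. Also open, going by these compounds, is whether fluoro here gives the same result with the unbranched chain of compound 1 or the hydroxy of compound 3.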